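Chain lengthening on a shared carbamate core and stability

The source may report more compounds than this note shows. Statements on the series, on what has been measured and on what is new or still open speak of the compounds shown alone.

Measured compounds:
compound 1, `CCNC(=O)Oc1ccc(Cl)cc1C(=O)Nc1ccc(Cl)cc1`, 64 h
compound 2, `CCCNC(=O)Oc1ccc(Cl)cc1C(=O)Nc1ccc(Cl)cc1`, 64 h
compound 3, `CCCCCCNC(=O)Oc1ccc(Cl)cc1C(=O)Nc1ccc(Cl)c(Cl)c1`, 64 h

Compounds 1 and 2 share one core, and compound 3 differs from them by a change that is not broken down here. In an ADME assay for metabolic stability, read by HPLC, at pH 7 (a higher number here means that the compound lasts longer, a lower number that the compound disappears faster), compound 1 gives 64 h, compound 2 gives 64 h and compound 3 gives 64 h. The change from compound 1 to compound 2 is methyl in place of hydrogen on a saturated chain carbon, two bonds along the chain from an amide-type nitrogen, and in this assay it gave no change at the digits printed from compound 1 to compound 2 (within the scatter).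

Compound 4, `CCCCCCCNC(=O)Oc1ccc(Cl)cc1C(=O)Nc1ccc(Cl)c(Cl)c1`, has not yet been measured. It differs from compound 3 by methyl in place of hydrogen on a saturated chain carbon, six bonds along the chain from an amide-type nitrogen. Among the compounds with values here, this is the same kind of change as the one from compound 1 to compound 2, though not the same: the methyl enters two bonds along the chain from an amide-type nitrogen in the earlier pair, but six bonds along the chain from an amide-type nitrogen here.

Compound 4 is expected to give 64 h in this assay, with a step from compound 3 of no change at the digits printed from compound 3 to compound 4 (within the scatter). This expectation rests on the earlier step, because no change at the digits printed from compound 1 to compound 2 (within the scatter), and on compound 3 giving 64 h.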

Compound 4, half-life: 64 h
For compound 4 middle estimate and measured number coincide at the digits printed; measured number inside the range.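

In this assay, the added methyl gave no change at the digits printed from compound 3 to compound 4 (within the scatter). Set beside the earlier step, the change carried from one core to the other with no difference that could be told from the scatter: the same change on two cores in this assay, no change at the digits printed (within the scatter) from compound 1 to compound 2 and no change at the digits printed (within the scatter) from compound 3 to compound 4, 1.0-fold (0.00 log units) apart, within the scatter of two such steps This does not show that the change would behave in the same way on a further core, since the comparison rests on only two pairs, in which the methyl enters at different places, two bonds and six bonds along the chain from an amide-type nitrogen, and it gives no cause for the agreement.

The compounds shown leave open whether a longer chain than that of compound 4, or a branched chain, would read the same in this assay. They also leave open what an amine or a carboxylic acid at the end of the chain would do on either core.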